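A few compounds are considered here, and "the series" means these few. Any claim that something is new, unique, unknown or untested is made for them only; others in the source may bear on it.

Compound 1 `COC(=O)C1=C(C)N(C)C(=O)NC1c1ccsc1`: 26%
Compound 2 `CCCOC(=O)C1=C(C)N(C)C(=O)NC1c1ccsc1`: 1%

In an assay on membranes from HEK293 cells for displacement of a labelled ligand from adenosine receptor A2b (Homo sapiens), read by scintillation counting, with a stated time of 30 min, tested at 1 uM (on this read-out higher numbers stand for more inhibition at the one concentration tested (going by the name of the read-out) and lower numbers for less inhibition), compound 1 gives 26%, while compound 2 gives 1%. Compound 2 thus stands lowest of the two, the step of a number 25 percentage points lower from compound 1 to compound 2 (beyond the scatter) being beyond the scatter. Compound 3 `CC1=C(C(=O)OC(C)(C)C)C(c2ccsc2)NC(=O)N1C` differs from compound 2 by tert-butyl in place of propyl on an oxygen next to a carbonyl group. Within the data shown here, the only measured step bearing on this position is a number 25 percentage points lower from compound 1 to compound 2 (beyond the scatter), a modest drop for an earlier change on the same oxygen; compound 2 already sits near the floor of the read-out, so little further movement is expected. For compound 3 the expected step is a number 1 percentage points higher from compound 2 to compound 3 (within the scatter), within the scatter. Compound 3 is therefore estimated at 2%, between -8% and 12%.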

Compound 3, a percentage reported as inhibition, at one concentration (the size of the read-out at that concentration, not a potency): 35%
For compound 3 the middle estimate is 33 percentage points below the measured one; the whole stated range lies below it.
By their numbers in this assay, from the lowest: compound 2; then compounds 1 and 3 (each within the scatter of the next).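

Replacing propyl with tert-butyl on this oxygen gives a number 34 percentage points higher from compound 2 to compound 3 (beyond the scatter) and reverses the loss seen with propyl, so adding carbon here does not simply lower the number. Replacing methyl with tert-butyl gives a number 9 percentage points higher from compound 1 to compound 3 (within the scatter) and leaves compound 1 and compound 3 unseparated, with compound 2 alone standing apart, so carbon count does not set the value across these compounds. Nothing available explains this difference.

As far as these compounds go, it remains open whether isopropyl or a longer chain on this oxygen would track compound 2 or compound 3, and how a carboxylic acid would compare.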